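The source may hold more compounds than are shown below. What is called first, only, known or untested is meant among the compounds shown, and "the series" means these compounds.

In a functional assay on HeLa cells (Homo sapiens) for antiproliferative activity, read by MTT assay, with a stated time of 3 days (a higher number here means a weaker inhibitor, a lower number a stronger inhibitor), compound 1 `O=C1c2ccccc2C(=O)N1C/C=C\Cn1cc(C#Cc2ccc(Br)cc2)c(=O)[nH]c1=O` gives 87000 nM. This lies within the scatter of the two other measured compounds: compound 2 `CCCCCC#Cc1cn(C/C=C/CN2C(=O)c3ccccc3C2=O)c(=O)[nH]c1=O` gives 91000 nM and compound 3 `CCCCc1ccc(C#Cc2cn(C/C=C/CN3C(=O)c4ccccc4C3=O)c(=O)[nH]c2=O)cc1` gives 94000 nM. Compound 4 `O=C1c2ccccc2C(=O)N1C/C=C\Cn1cc(C#CCCc2ccccc2)c(=O)[nH]c1=O` has not yet been measured. It differs from compound 1 as follows: phenethyl in place of 4-bromophenyl on a triple-bonded carbon. For the measured compounds named here, only one measured step changes the group on that carbon, a 1.0-fold higher number from compound 2 to compound 3 (0.01 log units; within the scatter), and it stayed within the scatter. On this single step, no change beyond the scatter is expected, so the expected step is a 1.0-fold higher number from compound 1 to compound 4 (0.01 log units; within the scatter). Compound 4 is estimated at 90000 nM, with an expected range from 50000 nM to 160000 nM.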

Compound 4, half-maximal inhibitory concentration: > 100000 nM
Compound 4: a limit, no number; the forecaster's own chance of this, stated with the estimate: 25%; middle value at least 1.1-fold (0.04 log units) away from the limit.
By their numbers in this assay, from the lowest: compounds 1, 2 and 3 (each within the scatter of the next). At a limit, above all of these: compound 4.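

In this assay compound 4 gives a limit of the assay, not a number: the limit of > 100000 nM in this assay, at which 1 of the 4 values shown sits.

Phenethyl in place of 4-bromophenyl on a triple-bonded carbon gives an at least 1.1-fold higher number from compound 1 to compound 4 (0.06 log units; that floor lies within the scatter), so only a floor for this step is known. Unlike the earlier steps at this carbon, this one has no upper end, and it could be small or large.

The compounds shown leave open how far compound 4 lies past its limit, and whether any group on this carbon gives a clearly lower number. Going by these compounds, what an amine or a carboxylic acid there would do also stays open.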